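The source may report more compounds than this note shows. Statements on the series, on what has been measured and on what is new or still open speak of the compounds shown alone.

Measured so far in a functional assay, read by spectrophotometry, with a stated time of 5 min; on this read-out higher numbers stand for weaker inhibition and lower numbers for stronger inhibition:

Compound 1 `O=c1cc(/C=N\c2ccccc2O)c2c(OCc3ccccc3)cc(OCc3ccccc3)cc2o1`: 33100 nM
Compound 2 `Nc1ccccc1/N=C\c1cc(=O)oc2cc(OCc3ccccc3)cc(OCc3ccccc3)c12`: 258000 nM
Compound 3 `Nc1ccccc1/N=C\c1cc(=O)oc2cc(OCc3ccccc3)ccc12`: 217000 nM

Compound 3 stands level with compound 2, the gap being a 1.2-fold lower number from compound 2 to compound 3 (0.08 log units; within the scatter). Compound 1 has a clearly lower number than both.

The next compound, compound 4 `O=c1cc(/C=N\O)c2ccc(OCc3ccccc3)cc2o1`, has not yet been measured. It differs from compound 3 by hydroxy in place of 2-aminophenyl on a double-bonded nitrogen.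

Within the data shown here, no measured step makes this exchange, so the evidence is indirect. The closest is a 7.8-fold higher number from compound 1 to compound 2 (0.89 log units; beyond the scatter), a modest step that put amino in place of hydroxy on an aromatic carbon, and compound 3 carries that amino. The other measured step, a 1.2-fold lower number from compound 2 to compound 3 (0.08 log units; within the scatter), put hydrogen in place of benzyloxy on an aromatic carbon, elsewhere in the molecule, and says little about this change. Compound 1, which keeps a hydroxy, gives 33100 nM, so a lower number is expected here, though with real uncertainty, since an entire ring leaves and nothing measured covers that. In this assay the expected change is a modest one, a 2.7-fold lower number from compound 3 to compound 4 (0.43 log units; beyond the scatter). For compound 4 the estimated value is 80000 nM, with an expected range from 15000 nM to 300000 nM.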

Compound 4, half-maximal inhibitory concentration: > 2000000 nM
Compound 4 ended at the assay's limit; the forecaster's own chance of this, stated with the estimate: 10%; middle value at least 25-fold (1.39 log units) from the limit.
By their numbers in this assay, from the lowest: compound 1; then compounds 3 and 2 (each within the scatter of the next). At a limit, above all of these: compound 4.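

In this assay compound 4 ended at a limit and not at a number: the limit of > 2000000 nM in this assay, at which 1 of the 4 values shown sits. Hydroxy in place of 2-aminophenyl on a double-bonded nitrogen gave an at least 9.2-fold higher number from compound 3 to compound 4 (0.96 log units; beyond the scatter), the first measured change at this position, and it shows that the position is not indifferent to what it carries. The earlier steps shown here only exchanged a group on an aromatic carbon, whereas this one removes a whole six-membered aromatic ring of carbon only, and the number rises in the direction of weaker inhibition even though the group that leaves and the group that enters each count one hydrogen-bond donor and one hydrogen-bond acceptor.

As far as these compounds go, the true size of the step stays unknown, as a limit fixes only how large it is at the least, and a single exchange cannot separate the loss of the ring from the loss of the amino on it or from the arrival of the hydroxy. Open too, from the compounds shown here alone, is whether a plain phenyl, a benzyl or a methoxy on the same double-bonded nitrogen would keep the number close to that of compound 3.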